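This account rests on a few compounds, and the source may have more. Where it says the series, first, only, none or still open, it means among the compounds named here.

Compound 1 `Nc1cc(N)c2nc(-c3ccccc3)c(NCc3ccc(Cl)c(Cl)c3)nc2c1`: 52500 nM
Compound 2 `Nc1cc(N)c2nc(-c3ccccc3)c(NCc3ccc(F)cc3)nc2c1`: 37200 nM

In a functional assay on CAKI-1 cells (Homo sapiens) for inhibition, read by sulforhodamine B assay, with a stated time of 48 h (on this read-out higher numbers stand for weaker inhibition of growth and lower numbers for stronger inhibition of growth), compound 2 and compound 1 sit within the scatter of each other, so neither stands apart on the numbers at hand. Among the compounds with values here, the single measured step, a 1.4-fold lower number from compound 1 to compound 2 (0.15 log units; within the scatter), is the only guide. Compound 3 `COc1ccc(CNc2nc3cc(N)cc(N)c3nc2-c2ccccc2)cc1` differs from compound 2 by methoxy in place of fluoro on an aromatic carbon. Within the data shown here, no measured step exchanges a fluoro for a methoxy, and the one step available stayed within the scatter, so compound 3 is expected to show no shift beyond the scatter in this assay, a step of a 1.1-fold higher number from compound 2 to compound 3 (0.03 log units; within the scatter). For compound 3 the estimate is 40000 nM, with a range from 15000 nM to 100000 nM.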

Compound 3, concentration for total growth inhibition: 36300 nM
Estimate against measurement, compound 3: 1.1-fold (0.04 log units) above, within the range that was stated.
By their numbers in this assay, from the lowest: compounds 3, 2 and 1 (each within the scatter of the next).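

In this assay, putting methoxy in place of fluoro on the aromatic carbon para to a large group gives a 1.0-fold lower number from compound 2 to compound 3 (0.01 log units; within the scatter) and so adds a hydrogen-bond acceptor at this place without a shift beyond the scatter. The exchange of 3,4-dichlorophenyl for 4-methoxyphenyl gives a 1.4-fold lower number from compound 1 to compound 3 (0.16 log units; within the scatter) and likewise stays within the scatter, so all three compounds remain together. Nothing at hand accounts for this closeness.

Going by these compounds, whether an amine, a carboxylic acid or a longer chain at this aromatic carbon would move the number beyond the scatter remains open.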